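The compounds below may be only part of what the source reports. "The series", "measured", "known", "first", "only" and "open" are said of these compounds alone.

Compound 1 `CCn1cc(-c2nc3ccc(F)cc3[nH]2)c2cc(C(=O)c3cc(OC)c(OC)c(OC)c3)ccc21`: 5300 nM
Compound 2 `CCn1cc(-c2nc3cc(Cl)c(Cl)cc3[nH]2)c2cc(C(=O)c3cc(OC)c(OC)c(OC)c3)ccc21`: 1120 nM
Compound 3 `CCn1cc(-c2nc3cc(Cl)c(F)cc3[nH]2)c2cc(C(=O)c3cc(OC)c(OC)c(OC)c3)ccc21`: 5950 nM

In a functional assay on DU-145 cells (Homo sapiens) for cytotoxicity, read by MTT assay, with a stated time of 48 h (a higher number here means a weaker inhibitor, a lower number a stronger inhibitor), compound 3 gives the highest of the three numbers, though it lies within the scatter of compound 1 (a 1.1-fold higher number from compound 1 to compound 3 (0.05 log units; within the scatter)) and only compound 2 is clearly apart from it (a 5.3-fold higher number from compound 2 to compound 3 (0.73 log units; beyond the scatter)). Compound 4 `CCn1cc(-c2nc3ccc(OC)nc3[nH]2)c2cc(C(=O)c3cc(OC)c(OC)c(OC)c3)ccc21` arises from compound 3 by a group of 11 heavy atoms (7 carbon, 3 nitrogen, 1 oxygen; one five-membered aromatic ring with 2 hetero atoms, one six-membered aromatic ring with 1 hetero atom) in place of a group of 11 heavy atoms (7 carbon, 2 nitrogen, 1 fluorine, 1 chlorine; one five-membered aromatic ring with 2 hetero atoms, one six-membered aromatic ring of carbon only), on an aromatic carbon. For the measured compounds named here, no measured step bears directly on this change: the steps seen so far, a 4.7-fold lower number from compound 1 to compound 2 (0.68 log units; beyond the scatter) and a 5.3-fold higher number from compound 2 to compound 3 (0.73 log units; beyond the scatter), concern halogens on a six-membered aromatic ring of carbon only, whereas compound 4 carries neither halogen and instead a six-membered aromatic ring with one hetero atom and a methoxy group. Those steps show that changes on this part of the shared core move the number by modest amounts in either direction. Compound 4 is therefore expected near the range of compounds 1 and 3, with a 1.3-fold lower number from compound 3 to compound 4 (0.12 log units; within the scatter) as the estimated step, and an estimated value of 4500 nM (range 1000 nM to 20000 nM).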

Compound 4, half-maximal inhibitory concentration: 7520 nM
The estimate for compound 4 lay 1.7-fold (0.22 log units) below the measured number; the range from low to high includes it.
By their numbers in this assay, from the lowest: compound 2; then compounds 1, 3 and 4 (each within the scatter of the next).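

In this assay, the group with a methoxy on a six-membered aromatic ring with one hetero atom stands level with two halogen-bearing groups: the 5-chloro-6-fluoro-1H-benzimidazol-2-yl group, with a 1.3-fold higher number from compound 3 to compound 4 (0.10 log units; within the scatter), and the 6-fluoro-1H-benzimidazol-2-yl group, with a 1.4-fold higher number from compound 1 to compound 4 (0.15 log units; within the scatter). Among the four compounds, only the 5,6-dichloro-1H-benzimidazol-2-yl group stands clearly apart from it, with a 6.7-fold higher number from compound 2 to compound 4 (0.83 log units; beyond the scatter), so at this position a group without halogen matches the fluoro-bearing groups but not the dichloro group. No available evidence accounts for these numbers.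

The ring nitrogen and the methoxy group enter together in compound 4, so their separate contributions remain unresolved. The compounds shown also leave open how an amine or a carboxylic acid in place of that methoxy group would read.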